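Phenyl-substituent changes on the bis-benzylidene cyclohexanone core

A few compounds are considered here, and "the series" means these few. Any claim that something is new, unique, unknown or untested is made for them only; others in the source may bear on it.

Measured so far:
compound 1, `O=C1/C(=C/c2ccccc2)CCC/C1=C\c1ccc(F)cc1`: 34%
compound 2, `O=C1/C(=C/c2ccccc2)CCC/C1=C\c1ccc(Br)cc1`: 29.1%

In an assay on isolated protein for inhibition of Alpha glucosidase (Homo sapiens), with stated times of 5 min and 15 min, tested at 50 uM (a higher number here means more inhibition at the concentration tested (going by the name of the read-out), a lower number less inhibition), compound 1 gives 34% and compound 2 gives 29.1%. On these two numbers compound 2 stands beside compound 1: a number 4.9 percentage points lower from compound 1 to compound 2 (within the scatter), so the two cannot be told apart.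

Compound 3, `O=C1/C(=C/c2ccccc2)CCC/C1=C\c1cccc(O)c1`, is the next member to be measured. It differs from compound 2 by 3-hydroxyphenyl in place of 4-bromophenyl on a double-bonded chain carbon bound to a double-bonded ring carbon. Within the data shown here, the only measured step, bromo in place of fluoro on an aromatic carbon, exchanges one halogen for another and was within the scatter; it does not speak to a hydroxyl group, nor to the shift of the substituent to the position named in the entering group. Among the measured compounds shown here, no measured step therefore bears directly on this change, and the expectation can only be anchored to the values of compound 1 and compound 2, which lie close together.

The expected outcome is a step of about a number 2.9 percentage points higher from compound 2 to compound 3 (within the scatter), not beyond the scatter in either direction. Compound 3 is estimated to give 32% in this assay, within a range from 15% to 50%.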

Compound 3, a percentage reported as inhibition, at one concentration (the size of the read-out at that concentration, not a potency): 65.1%
The estimate for compound 3 lay 33.1 percentage points below the measured number; measured number outside the range, above it.
By their numbers in this assay, from the lowest: compounds 2 and 1 (each within the scatter of the next); then compound 3.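

In this assay this place on the shared core turns out to be sensitive to the group it carries: 3-hydroxyphenyl in place of 4-bromophenyl gives a number 36 percentage points higher from compound 2 to compound 3 (beyond the scatter) and 3-hydroxyphenyl in place of 4-fluorophenyl gives a number 31.1 percentage points higher from compound 1 to compound 3 (beyond the scatter) at the same double-bonded chain carbon bound to a double-bonded ring carbon. Among these compounds, the exchange of one halogen for the other had left the read-out within the scatter, so compound 3 is the first to stand clearly apart, and it does so from both halogen-bearing compounds. Nothing at hand bears on the reason for these steps.

The change swaps the substituent and its ring position together, so the compounds shown cannot say whether the hydroxyl group itself or its placement carries the step. Also open, going by these compounds, is how a methoxy group, an amine or a carboxylic acid would read in place of that hydroxyl, and whether a second hydroxyl on the other phenyl ring of the core would add anything.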